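Fluoro Enters the Phenyl of Compound 1 at a New Place

The source may report more compounds than this note shows. Statements on the series, on what has been measured and on what is new or still open speak of the compounds shown alone.

Compound 1 `c1ccc(-c2cn3ccnc3c(-c3ccc4ncn(C5CCCCC5)c4c3)n2)cc1` is the reference point of this small set. In a functional assay on NCI/ADR-RES cells (Homo sapiens) for inhibition, read by sulforhodamine B assay, with a stated time of 48 h, tested at 10 uM (a lower number here means less inhibition, a higher number more inhibition at the concentration tested (going by the name of the read-out)), compound 1 gives 50.5%, which is the highest of the two numbers recorded. Among the measured compounds shown here, its only measured neighbour, compound 2 `Fc1ccc(-c2cn3ccnc3c(-c3ccc4ncn(C5CCCCC5)c4c3)n2)cc1`, gives 0.69% in this assay, and the step from one to the other, a number 49.8 percentage points lower from compound 1 to compound 2 (beyond the scatter), is well beyond the scatter of repeated measurements.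

Compound 3 `Fc1ccccc1-c1cn2ccnc2c(-c2ccc3ncn(C4CCCCC4)c3c2)n1` has not yet been measured. It differs from compound 1 by fluoro in place of hydrogen on an aromatic carbon, the fluorine now sitting on an aromatic carbon of the phenyl ring ortho to a large group, so that the phenyl becomes a 2-fluorophenyl. For the measured compounds named here, the only measured step that bears on this change is the one from compound 1 to compound 2, where the same kind of substitution at a different carbon of the same ring removed almost all of the inhibition. On that single precedent a drop is expected here as well, though the place of the fluorine differs, so the size is uncertain.

For compound 3 the estimate is 20%, with a range from 0% to 50%, meaning an expected step of a number 30.5 percentage points lower from compound 1 to compound 3 (beyond the scatter).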

Compound 3, a percentage reported as inhibition, at one concentration (the size of the read-out at that concentration, not a potency): 4.51%
Beside the measured number, compound 3's estimate is 15.5 percentage points above it; the range from low to high includes it.
By their numbers in this assay, from the lowest: compounds 2 and 3 (each within the scatter of the next); then compound 1.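

In this assay the step of a number 46 percentage points lower from compound 1 to compound 3 (beyond the scatter) shows that the loss is not tied to the single carbon of the phenyl ring changed in compound 2, since fluoro on an aromatic carbon ortho to a large group also removes most of the inhibition. The step of a number 3.8 percentage points higher from compound 2 to compound 3 (within the scatter) lies within the scatter, so the 2-fluorophenyl and the 4-fluorophenyl cannot be told apart in this read-out, and both sit far from the unsubstituted phenyl of compound 1. At these low numbers, the two places on the ring therefore give no ranking, and nothing available accounts for the loss at either place.

The compounds shown leave open whether the loss belongs to fluoro itself or would also follow another group at these places on the phenyl, such as chloro, methoxy, an amine or a carboxylic acid. They also cannot say whether any substituent on this ring can keep the inhibition of compound 1, or whether this holds with a change elsewhere on the shared core.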